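Inverting the sulfur stereocentre of compound 1

The source may report more compounds than this note shows. Statements on the series, on what has been measured and on what is new or still open speak of the compounds shown alone.

Compound 1 `O=[N+]([O-])c1cn2c(n1)[S@@+]([O-])C[C@@H](OCc1ccc(OC(F)(F)F)cc1)C2` is the starting point for this step. In an ADME assay on L929 cells (Mus musculus) for cytotoxicity (a lower number here means a stronger inhibitor, a higher number a weaker inhibitor), compound 1 gives > 10 ug/mL as its reading, which is a limit of the assay and not a number. Compound 2 `O=[N+]([O-])c1cn2c(n1)OCC(COc1ccc(-c3ccc(C(F)(F)F)cc3)nc1)C2` gives > 10 ug/mL as its reading, again a limit of the assay. The evidence so far amounts to the limit of > 10 ug/mL in this assay, at which 2 of the 2 values shown sit, with no numeric reading behind it. Compound 3 `O=[N+]([O-])c1cn2c(n1)[S@+]([O-])C[C@@H](OCc1ccc(OC(F)(F)F)cc1)C2` is not yet measured, and its difference from compound 1 is the two compounds have the same atoms and bonds and differ only in configuration as drawn: 1 of 2 stereo elements differ; a stereocentre at a sulfur is drawn S in compound 1 and R in compound 3 with no other change. Within the data shown here, no measured step shows what this inversion does in this assay so a change beyond the scatter is not expected, and no direction is favoured. The expected step that the limit leaves unreadable from compound 1 to compound 3 is an estimate resting on that absence of evidence. For compound 3 the expected value is 15 ug/mL with an estimated range from 10 ug/mL to 40 ug/mL and a reading at the limit remains likely.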

Compound 3, half-maximal inhibitory concentration: > 10 ug/mL
Compound 3: no number, only a limit; the forecaster's own chance of this, stated with the estimate: 85%; the middle value does not contradict the limit.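

In this assay no step can be read between compound 1 and compound 3, which differ only at the sulfur stereocentre, as both readings are limits of the assay and not numbers: the limit of > 10 ug/mL in this assay, at which 3 of the 3 values shown sit. On these data alone, whether that inversion changes the cytotoxicity reading at all stays open.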